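Furan-3-yl for Cyclopropyl: an Expected Gain in Binding

The source may hold more compounds than are shown below. What is called first, only, known or untested is meant among the compounds shown, and "the series" means these compounds.

Compound 1 `Cc1sc2nc(-c3ccoc3)[nH]c(=O)c2c1C`: 398 nM
Compound 2 `O=C(Nc1nc(C2CC2)cs1)c1cc2ccccc2s1`: 33.9 nM; 40 nM (2 entries)
Compound 3 `CCc1cc2c(=O)[nH]c(C3CC3)nc2s1`: 1820 nM

In an assay on CRE-SPAP cells for displacement of a labelled ligand from transmembrane domain-containing protein TMIGD3 (Homo sapiens), read by fluorescence, with a stated time of 1 h (on this read-out lower numbers stand for stronger inhibition and higher numbers for weaker inhibition), compound 3 gives 1820 nM, the highest of the two plain numbers shown; compound 1 gives 398 nM, a lower number, and that gap lies beyond the scatter. Compound 2 has several entries, (the several entries of compound 2 in this assay, 33.9 nM; 40 nM (2 entries)). Compound 4 `CCc1cc2c(=O)[nH]c(-c3ccoc3)nc2s1` is yet to be measured and differs from compound 3 in one place: furan-3-yl in place of cyclopropyl on an aromatic carbon. For the measured compounds named here, no single-change step between measured compounds is known, so the size of this step is open. Compound 1 carries the same furan-3-yl and stands lower than compound 3, though it differs elsewhere as well; a step to a lower number in this assay, beyond the scatter, is expected. Compound 4 is estimated at 500 nM (range 150 nM to 1500 nM). The expected step is a 3.6-fold lower number from compound 3 to compound 4 (0.56 log units; beyond the scatter).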

Compound 4, inhibition constant: 550 nM
Beside the measured number, compound 4's estimate is 1.1-fold (0.04 log units) below it; measured number inside the range.
By their numbers in this assay, from the lowest: compounds 1 and 4 (each within the scatter of the next); then compound 3.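

In this assay, for the compounds shown here, furan-3-yl in place of cyclopropyl on the aromatic carbon between two ring nitrogen atoms gives a 3.3-fold lower number from compound 3 to compound 4 (0.52 log units; beyond the scatter) and so provides the first single-change step at this position. The position therefore accepts a five-membered aromatic ring with 1 hetero atom, and the number moves to a modest degree in the stronger direction. Nothing available accounts for the size of this step.

On these data alone, whether an amine, a phenyl ring or a longer chain at this position would give a lower or a higher number remains open. As far as these compounds go, it is also open whether the same step would appear on the core of compound 1.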